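The source may hold more compounds than are shown below. What is called first, only, known or untested is meant among the compounds shown, and "the series" means these compounds.

Measured compounds:
Compound 1, `COC(=O)[C@@]1(C)CCC=C2[C@@H]1CC[C@@H](C)[C@]2(C)Cc1c[nH]c2ccccc12`: in a functional assay on T47D cells (Homo sapiens) for inhibition, read by sulforhodamine B assay, with a stated time of 48 h (a higher number here means a weaker inhibitor of growth, a lower number a stronger inhibitor of growth), compound 1 gives 4200 nM.
Compound 2, `COC(=O)[C@@]1(C)CCC=C2[C@@H]1CC[C@@H](C)[C@]2(C)Cc1c[nH]c2c(Cl)cccc12`: in this assay compound 2 gives 24000 nM.
Compound 3, `COC(=O)[C@@]1(C)CCC=C2[C@@H]1CC[C@@H](C)[C@]2(C)Cc1c(C)[nH]c2ccccc12`: in this assay compound 3 gives 17000 nM.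

Compound 3 stands second highest of the three numbers; its gap to compound 2 is within the scatter, while the step of a 4.0-fold higher number from compound 1 to compound 3 (0.61 log units; beyond the scatter) lies beyond it. Compound 4, `COC(=O)[C@@]1(C)CCC=C2[C@@H]1CC[C@@H](C)[C@]2(C)Cc1c(C)[nH]c2ccc(OC)cc12`, differs from compound 3 by a single change: methoxy in place of hydrogen on an aromatic carbon. Among the measured compounds shown here, no measured pair shows this exact change. The two steps that come closest are both additions of a small group to an aromatic carbon of the shared core: a 5.7-fold higher number from compound 1 to compound 2 (0.76 log units; beyond the scatter) and a 4.0-fold higher number from compound 1 to compound 3 (0.61 log units; beyond the scatter). Both raised the number, and each was modest. On that basis the expected outcome for compound 4 in this assay is a small rise in the number, or no step beyond the scatter, as estimated by a 1.5-fold higher number from compound 3 to compound 4 (0.17 log units; within the scatter). Compound 4 is therefore expected to give about 25000 nM, with a range from 8000 nM to 70000 nM.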

Compound 4, concentration for 50% growth inhibition: 15000 nM
Estimate against measurement, compound 4: 1.7-fold (0.22 log units) above; the range from low to high includes it.
By their numbers in this assay, from the lowest: compound 1; then compounds 4, 3 and 2 (each within the scatter of the next).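

In this assay, putting methoxy in place of hydrogen on this aromatic carbon gives a 1.1-fold lower number from compound 3 to compound 4 (0.05 log units; within the scatter), a step that cannot be told apart from no change at all. The earlier additions to aromatic carbons of the shared core, chloro with a 5.7-fold higher number from compound 1 to compound 2 (0.76 log units; beyond the scatter) and methyl with a 4.0-fold higher number from compound 1 to compound 3 (0.61 log units; beyond the scatter), both lay beyond the scatter, so the new step shows that such an addition does not always raise the number. No measured evidence bears on this result.

Methoxy appears here only on a compound that also carries the methyl group of compound 3, so its effect on compound 1 remains open. Also open, as far as these compounds go, is how an amine, a carboxylic acid or a longer chain such as butoxy would behave on this same carbon.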